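Swapping Bromo for Nitro in a Narrow Cytotoxicity Series

This account rests on a few compounds, and the source may have more. Where it says the series, first, only, none or still open, it means among the compounds named here.

In a functional assay on HepG2 cells (Homo sapiens) for cytotoxicity, read by MTT assay, with a stated time of 72 h (a higher number here means a weaker inhibitor, a lower number a stronger inhibitor), compound 1 (`O=C1C=CCC/C1=C\C=C\c1ccccc1`) gives 7100 nM, compound 2 (`O=C1C=CCC/C1=C\C=C\c1ccc(Cl)cc1`) gives 3700 nM and compound 3 (`O=C1C=CCC/C1=C\C=C\c1ccc(Br)cc1`) gives 6100 nM. Compound 3 therefore lies within the scatter of both others. Compound 4 (`O=C1C=CCC/C1=C\C=C\c1ccc([N+](=O)[O-])cc1`) carries nitro in place of bromo on an aromatic carbon, para to a large group (nitro in place of bromo on an aromatic carbon). Among the measured compounds shown here, no nitro compound has been measured yet, so only the chloro and bromo steps bear on this change: a 1.9-fold lower number from compound 1 to compound 2 (0.28 log units; within the scatter), a 1.2-fold lower number from compound 1 to compound 3 (0.07 log units; within the scatter) and a 1.6-fold higher number from compound 2 to compound 3 (0.22 log units; within the scatter). All three are small, so no shift beyond the scatter is expected. The expected step is a 1.5-fold lower number from compound 3 to compound 4 (0.18 log units; within the scatter). For compound 4 the estimated value is 4000 nM, with an expected range of 1500 nM to 10000 nM.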

Compound 4, half-maximal inhibitory concentration: 4900 nM
Estimate against measurement, compound 4: 1.2-fold (0.09 log units) below, and the stated range covers the measured number.
By their numbers in this assay, from the lowest: compounds 2, 4, 3 and 1 (each within the scatter of the next).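

In this assay, nitro on this aromatic carbon, para to a large group, stays within the scatter of bromo, chloro and hydrogen: a 1.2-fold lower number from compound 3 to compound 4 (0.10 log units; within the scatter), a 1.3-fold higher number from compound 2 to compound 4 (0.12 log units; within the scatter) and a 1.4-fold lower number from compound 1 to compound 4 (0.16 log units; within the scatter). The place thus takes a group with hydrogen-bond acceptors and more heavy atoms without any step beyond the scatter. Nothing available accounts for this flat result.

Going by these compounds, whether an amine or a carboxylic acid on this aromatic carbon would give a step beyond the scatter stays open. So does the effect of any change to the shared core.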